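The source may hold more compounds than are shown below. What is called first, only, known or untested is meant among the compounds shown, and "the series" means these compounds.

Measured so far:
Compound 1, `O=C(CCc1ccc(Oc2ccccc2)cc1)c1ncc(C(F)(F)F)o1`: 1 nM
Compound 2, `COC(=O)c1cccc(-c2cnc(C(=O)CCc3ccc(-c4ccccc4)cc3)o2)n1`: 1.2 nM

Both numbers come from an assay on COS-7 cells for inhibition of Fatty-acid amide hydrolase 1 (Homo sapiens); a lower number here means a stronger inhibitor, a higher number a weaker inhibitor. Compound 1 holds the lowest of the two numbers, but the gap to compound 2 lies within the usual scatter of repeated measurements, so on these numbers the two compounds cannot be told apart. Among the compounds with values here, compound 2 differs from compound 1 in more than one place, so no single step between measured compounds has been traced.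

The next compound, compound 3, `N#Cc1cnc(C(=O)CCc2ccc(Oc3ccccc3)cc2)o1`, has not yet been measured. It departs from compound 1 in one place only: cyano in place of trifluoromethyl on an aromatic carbon. Within the data shown here, no measured pair shows this kind of exchange, so there is nothing directly comparable to lean on. Because compound 1 gives 1 nM in this assay, the starting point is a very low number, and a small step toward a higher number seems the most likely outcome, although a step lying within the scatter cannot be ruled out. The step from compound 1 to compound 3 is expected to be modest, a 3.0-fold higher number from compound 1 to compound 3 (0.48 log units; beyond the scatter). Compound 3 is therefore expected to give about 3 nM, with a plausible range from 0.8 nM to 12 nM.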

Compound 3, inhibition constant: 0.85 nM
Compound 3: the middle estimate sits 3.5-fold (0.55 log units) above what was measured, within the range that was stated.
By their numbers in this assay, from the lowest: compounds 3, 1 and 2 (each within the scatter of the next).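

Within the data shown here, this is the first change traced to a single place, the aromatic carbon next to the ring oxygen, and in this assay the exchange of trifluoromethyl for cyano gives a 1.2-fold lower number from compound 1 to compound 3 (0.07 log units; within the scatter). The group at this place can therefore go from four heavy atoms to two, and gain one hydrogen-bond acceptor, with no change that can be told apart from the scatter, so compound 1 and compound 3 stand level on these numbers. Nothing available here explains why the two groups give such similar numbers.

The compounds shown leave open how far this place stays so undemanding, for instance whether an amine, a carboxylic acid or a bare hydrogen there would keep the number in the same range. They also leave open whether the same exchange would give so small a step with a longer chain joining the carbonyl to the aromatic ring system that compound 1 and compound 3 share.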